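From 2-fluorophenyl to 1-benzofuran-4-yl: series notes

The compounds below may be only part of what the source reports. "The series", "measured", "known", "first", "only" and "open" are said of these compounds alone.

Values in a physicochemical assay for solubility; a higher number here means a more soluble compound, a lower number a less soluble compound:
- Compound 1 `CNC(=O)c1cc(C(=O)NC2CC2)cn(Cc2nccc3[nH]ccc23)c1=O`: 73 ug/mL
- Compound 2 `CNC(=O)c1cc(C(=O)NC2CC2)cn(Cc2cccc3[nH]ncc23)c1=O`: 10 ug/mL
- Compound 3 `CNC(=O)c1cc(C(=O)NC2CC2)cn(Cc2ccccc2F)c1=O`: >= 145 ug/mL

Compound 3 gives only a limit of the assay, >= 145 ug/mL, and no number. Compound 4 `CNC(=O)c1cc(C(=O)NC2CC2)cn(Cc2cccc3occc23)c1=O` replaces the 2-fluorophenyl with 1-benzofuran-4-yl on a saturated chain carbon bound to an aromatic nitrogen: 1-benzofuran-4-yl in place of 2-fluorophenyl on a saturated chain carbon bound to an aromatic nitrogen.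

Two measured steps exchange 2-fluorophenyl with a two-ring group. The closer is an at least 14-fold higher number from compound 2 to compound 3 (1.16 log units; beyond the scatter), a large step, since 1H-indazol-4-yl also has a six-membered aromatic ring of carbon only. The other, an at least 1.9-fold higher number from compound 1 to compound 3 (0.29 log units; that floor lies within the scatter), has a floor within the scatter. The two-ring groups also differ from each other, with a 7.3-fold lower number from compound 1 to compound 2 (0.86 log units; beyond the scatter) beyond the scatter. Read in reverse, these steps suggest a lower number in this assay, probably beyond the scatter. The expected step is an at least 7.2-fold lower number from compound 3 to compound 4 (0.86 log units; beyond the scatter). For compound 4 the estimated value is 20 ug/mL, with an expected range of 6 ug/mL to 70 ug/mL.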

Compound 4, solubility: >= 110 ug/mL
Compound 4 was reported as a limit; the forecaster's own chance of this, stated with the estimate: 5%; middle value at least 5.5-fold (0.74 log units) away from the limit.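

In this assay, the 1-benzofuran-4-yl group shows that a two-ring group on a saturated chain carbon bound to an aromatic nitrogen need not bring the low value seen with 1H-indazol-4-yl: the change gives an at least 11-fold higher number from compound 2 to compound 4 (1.04 log units; beyond the scatter). Against the two-ring group of compound 1, the change gives an at least 1.5-fold higher number from compound 1 to compound 4 (0.17 log units; that floor lies within the scatter), so no order between these two groups can be claimed. The step between compound 3 and compound 4 cannot be read, the value of compound 4 being a limit and not a number: the limit of >= 110 ug/mL in this assay, at which 1 of the 4 values shown sits.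

From the compounds shown here alone, whether 1-benzofuran-4-yl and 2-fluorophenyl truly differ stays open, compound 3 also being a limit: the limit of >= 145 ug/mL in this assay, at which 1 of the 4 values shown sits. Also open is how a 1-benzofuran-4-yl group carrying a carboxylic acid or a dimethylamino group would read in this assay.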